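Taking the 2-hydroxyethoxy group off compound 1

A few compounds are considered here, and "the series" means these few. Any claim that something is new, unique, unknown or untested is made for them only; others in the source may bear on it.

Measured in a functional assay for inhibition (on this read-out higher numbers stand for weaker inhibition and lower numbers for stronger inhibition), so far:
compound 1 `CC(C)(C)c1cc(-c2cc(=O)c3ccc(OCCO)cc3o2)cc(C(C)(C)C)c1O` gives 3000 nM here
compound 2 `CC(C)(C)c1cc(-c2cc(=O)c3ccc(OCc4ccc(Cl)cc4)cc3o2)cc(C(C)(C)C)c1O` gives 7000 nM here
compound 3 `CCOC(=O)C(C)(C)Oc1ccc2c(=O)cc(-c3cc(C(C)(C)C)c(O)c(C(C)(C)C)c3)oc2c1` gives 3000 nM here

Compound 1 stands level with compound 3, and the two share the lowest number of the three. Still unmeasured, compound 4 `CC(C)(C)c1cc(-c2cc(=O)c3ccccc3o2)cc(C(C)(C)C)c1O` keeps the core of compound 1 but differs by hydrogen in place of 2-hydroxyethoxy on an aromatic carbon.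

The measured steps all exchange the group on an oxygen on an aromatic ring. They show no change at the digits printed from compound 1 to compound 3 (within the scatter), then a 2.3-fold higher number from compound 1 to compound 2 (0.37 log units; beyond the scatter), and a 2.3-fold lower number from compound 2 to compound 3 (0.37 log units; beyond the scatter) in this small set. Across these three compounds, the number therefore moved modestly at most. None of the steps removes the oxygen itself, so they bear on this change only indirectly.

In this assay a step no larger than these is expected, most likely none beyond the scatter and, if any, slightly upward. The estimated step is a 1.3-fold higher number from compound 1 to compound 4 (0.12 log units; within the scatter) for now. Compound 4 is expected at 4000 nM, with an estimated range of 1500 nM to 10000 nM for that compound.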

Compound 4, half-maximal inhibitory concentration: 3000 nM
Compound 4: middle estimate off by 1.3-fold (0.12 log units), on the high side; the range from low to high includes it.
By their numbers in this assay, from the lowest: compounds 1, 3 and 4 (each within the scatter of the next); then compound 2.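

Removing the oxygen-linked group altogether gives no change at the digits printed from compound 1 to compound 4 (within the scatter) and no change at the digits printed from compound 3 to compound 4 (within the scatter) in this assay, so at this aromatic carbon neither 2-hydroxyethoxy nor 1-(ethoxycarbonyl)-1-methylethoxy separates from plain hydrogen. The one step beyond the scatter is a 2.3-fold lower number from compound 2 to compound 4 (0.37 log units; beyond the scatter), which leaves (4-chlorobenzyl)oxy as the only group shown here that differs from hydrogen, and only modestly. No evidence is available to explain these numbers.

Going by these compounds, whether an amine or a carboxylic acid at this carbon would also stay level with hydrogen remains open, as does whether a longer chain on the oxygen would shift the number further than (4-chlorobenzyl)oxy does. The compounds shown also leave open how changes elsewhere on the shared core would read.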